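Metabolic stability across the chain-carbon substituents of the series

The source may report more compounds than this note shows. Statements on the series, on what has been measured and on what is new or still open speak of the compounds shown alone.

Compound 1 `CC(C)C(c1nnc[nH]1)c1ccc(-c2ccc3cccc(F)c3c2)[nH]c1=O` holds the highest number of the three measured; in an ADME assay on microsomes from liver (Homo sapiens) for metabolic stability (on this read-out higher numbers stand for a longer-lived compound and lower numbers for a shorter-lived compound), compound 1 gives 0.905 h. Compound 3 `CC(C)C(/C=C1\CCNC1=O)c1ccc(-c2ccc3cccc(F)c3c2)[nH]c1=O` gives 0.713 h, and compound 2 `CC(C)C(c1ccc(-c2ccc3cccc(F)c3c2)[nH]c1=O)N1CCCCC1=O` gives 0.183 h. Compound 4 `CC(C)C(Cc1noc(=O)[nH]1)c1ccc(-c2ccc3cccc(F)c3c2)[nH]c1=O` is unmeasured; it differs from compound 1 as follows: a group of 7 heavy atoms (3 carbon, 2 nitrogen, 2 oxygen; one five-membered aromatic ring with 3 hetero atoms) in place of a group of 5 heavy atoms (2 carbon, 3 nitrogen; one five-membered aromatic ring with 3 hetero atoms), on a saturated chain carbon bound to an aromatic carbon and a saturated chain carbon. Within the data shown here, two steps bear on it, both exchanging the same group on the same carbon: a 4.9-fold lower number from compound 1 to compound 2 (0.69 log units; beyond the scatter) and a 1.3-fold lower number from compound 1 to compound 3 (0.10 log units; within the scatter). One step lowered this assay modestly, the other stayed within the scatter; the entering group of compound 4 keeps a five-membered aromatic ring with 3 hetero atoms, as in compound 1. A small downward step, or none beyond the scatter, is expected: a 1.5-fold lower number from compound 1 to compound 4 (0.18 log units; within the scatter). Compound 4 is estimated at 0.6 h, between 0.3 h and 1.2 h.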

Compound 4, half-life: > 3 h
Compound 4: a limit, no number; the forecaster's own chance of this, stated with the estimate: 5%; at least 5.0-fold (0.69 log units) between middle value and limit.
By their numbers in this assay, from the lowest: compound 2; then compounds 3 and 1 (each within the scatter of the next). At a limit, above all of these: compound 4.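

In this assay compound 4 stands at a limit, not a number: the limit of > 3 h in this assay, at which 1 of the 4 values shown sits. On this saturated chain carbon the earlier exchanges only lowered the number or stayed within the scatter, whereas this one gives an at least 3.3-fold higher number from compound 1 to compound 4 (0.52 log units; beyond the scatter). The same entering group also gives an at least 4.2-fold higher number from compound 3 to compound 4 (0.62 log units; beyond the scatter) and an at least 16-fold higher number from compound 2 to compound 4 (1.21 log units; beyond the scatter), so a retained five-membered aromatic ring with 3 hetero atoms does not by itself fix the read-out.

Open, as far as these compounds go, is whether the ring or its carbon link in the entering group carries the step. A carboxylic acid on that same link would bear on this.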